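The source may hold more compounds than are shown below. What is called first, only, known or untested is meant among the compounds shown, and "the series" means these compounds.

Series notes. Compound 1 `Cc1cccc(Cc2cnc(CCc3ccc(-c4ccccc4C(=O)O)cc3)[nH]2)c1` gives 75 nM in an in vitro functional assay on cells for agonist activity at Bombesin receptor subtype-3 (Mus musculus), read by luminescence and calcium flux (a lower number here means that less compound is needed, a higher number that more compound is needed for the effect), and holds the lowest of the two numbers in hand. Compound 2 `CCCCc1cnc(C(Cc2ccc(-c3ccccc3C(=O)O)cc2)C(C)C)[nH]1` gives 2240 nM in this assay, a gap from compound 1 that lies beyond the usual scatter. For compound 3 `CCCCc1cnc(Cc2ccc(-c3ccccc3C(=O)O)cc2)[nH]1` the this assay reports only a limit, > 10000 nM, and no number. The next compound, compound 4 `O=C(O)c1ccccc1-c1ccc(CCc2ncc(Cc3ccc(F)cc3)[nH]2)cc1`, differs from compound 1 in one place: 4-fluorophenyl in place of 3-methylphenyl on a saturated chain carbon bound to an aromatic carbon. Among the compounds with values here, no measured pair shows this change, so the size of the step is open. Compound 4 is expected to stay close to its parent, with a step of a 2.0-fold higher number from compound 1 to compound 4 (0.30 log units; within the scatter) near the edge of the scatter toward a higher number. Compound 4 is therefore estimated at 150 nM, with a range from 50 nM to 500 nM.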

Compound 4, half-maximal effective concentration: 50 nM
Compound 4: middle estimate off by 3.0-fold (0.48 log units), on the high side; low and high end bracket the measured number.
By their numbers in this assay, from the lowest: compounds 4 and 1 (each within the scatter of the next); then compound 2. At a limit, above all of these: compound 3.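

Within the data shown here, the first one-place pair reads a 1.5-fold lower number from compound 1 to compound 4 (0.18 log units; within the scatter) in this assay, so on this saturated chain carbon bound to an aromatic carbon, 3-methylphenyl and 4-fluorophenyl cannot be told apart. The substituent and its ring position change together here, and the step stays within the scatter. No measured property among the compounds shown bears on this step.

The separate contributions of the methyl group, the fluorine and their ring positions remain unresolved. From the compounds shown here alone, whether this place also accepts unsubstituted phenyl, a pyridine ring or a cyclohexyl ring stays open.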